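The source may report more compounds than this note shows. Statements on the series, on what has been measured and on what is new or still open speak of the compounds shown alone.

Among the compounds with values here, in a functional assay on MT4 cells (Homo sapiens) for inhibition (on this read-out higher numbers stand for weaker inhibition and lower numbers for stronger inhibition), compound 1 `C=C1C(n2ccc(N)nc2=O)O[C@H](CO)[C@@H]1O` gives 190 nM, the only true number among the three compounds measured so far. Compound 2 `C=C1[C@@H](O)[C@H](n2cnc3c(Cl)nc(N)nc32)O[C@@H]1CO` reads > 500000 nM, which is a limit of the assay and not a number. Compound 3 `C=C1[C@@H](O)[C@H](n2cnc3c(O)nc(N)nc32)O[C@@H]1CO` reads > 200000 nM, which is also a limit, so its true position is not known.

Compound 4 `C=C1[C@@H](O)[C@H](n2cnc3c(OC)nc(N)nc32)O[C@@H]1CO` differs from compound 3 by a single change: methyl in place of hydrogen on an oxygen on an aromatic ring. This is methyl in place of hydrogen on an oxygen on an aromatic ring, or hydroxy to methoxy.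

Within the data shown here, only one measured step bears on this change: a step that the two limits leave unreadable from compound 2 to compound 3, with hydroxy in place of chloro on an aromatic carbon. Both of its ends are limits, so it gives no size and no direction to carry over. The expectation in this assay is therefore no step beyond the scatter, with compound 4 staying in the same very weak range and quite possibly reported only as a limit. The expected change is a step that the limit leaves unreadable from compound 3 to compound 4. For compound 4 the estimate is 250000 nM, with an expected range from 70000 nM to 600000 nM.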

Compound 4, half-maximal inhibitory concentration: > 500000 nM
Compound 4 ended at the assay's limit; the forecaster's own chance of this, stated with the estimate: 75%; middle value at least 2.0-fold (0.30 log units) away from the limit.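

Within the data shown here, compound 2, compound 3 and compound 4 all read as limits in this assay and not as numbers, so no step among them can be read. The compounds shown leave open whether chloro, hydroxy and methoxy on the shared core differ in inhibition at all.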